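Swapping the aryl ether of compound 1 for an aryl thioether

The source may hold more compounds than are shown below. What is called first, only, known or untested is meant among the compounds shown, and "the series" means these compounds.

Compound 1, `Nc1cc(N)c2nc(-c3ccccc3)c(Oc3ccc(Cl)c(Cl)c3)nc2c1`: 91200 nM
Compound 2, `CCOC(=O)[C@H](CCC(=O)O)NC(=O)c1ccc(CNc2nc3cc(N)cc(N)c3nc2-c2ccccc2)cc1`: < 100000 nM, a limit of the assay and not a number
Compound 3, `CCOC(=O)[C@H](CCC(=O)O)NC(=O)c1ccc(Sc2nc3cc(N)cc(N)c3nc2-c2ccccc2)cc1`: < 100000 nM, a limit of the assay and not a number

Three compounds sharing one core were examined in a functional assay on IGROV-1 cells (Homo sapiens) for inhibition, read by sulforhodamine B assay, with a stated time of 48 h; a lower number here means that less compound is tolerated, a higher number that more compound is tolerated. Among the measured compounds shown here, compound 1 gives 91200 nM, the only actual number in this set. For compound 2 the assay returned only a limit, < 100000 nM. For compound 3 the assay likewise returned only a limit, < 100000 nM. Compound 1 therefore stands as the sole fixed point; the two other entries sit at the limit of < 100000 nM in this assay, at which 2 of the 3 values shown sit, and cannot be ranked against it.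

The next compound, compound 4, `COc1ccc(Sc2nc3cc(N)cc(N)c3nc2-c2ccccc2)cc1`, has not yet been measured in this assay. It differs from compound 1 in a single place: (4-methoxyphenyl)sulfanyl in place of 3,4-dichlorophenoxy on an aromatic carbon. For the measured compounds named here, no pair of measured compounds shows this kind of change, so there is no measured step to lean on. Compound 1 stands at 91200 nM. The two other values give no second fixed point. The expectation is that the step from compound 1 to compound 4 will be a 1.1-fold lower number from compound 1 to compound 4 (0.03 log units; within the scatter), within or close to the scatter, with the possibility that this assay again reports only a limit. The estimate for compound 4 is 85000 nM, with a range from 30000 nM to 160000 nM.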

Compound 4, concentration lethal to 50% of the cells: < 100000 nM
Compound 4: no number, only a limit; the forecaster's own chance of this, stated with the estimate: 40%; the middle value lies beyond the limit too.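

In this assay compound 4 gives < 100000 nM, a limit of the assay and not a number, so the step to it from compound 1 cannot be read: the limit of < 100000 nM in this assay, at which 3 of the 4 values shown sit.

The compounds shown leave open whether (4-methoxyphenyl)sulfanyl in place of 3,4-dichlorophenoxy shifts the reading in this assay at all, and in which direction.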